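The source may report more compounds than this note shows. Statements on the series, on what has been measured and on what is new or still open speak of the compounds shown alone.

Compound 1 `COc1cc(/C=C/C(=O)c2cc3cc(O)ccc3oc2=O)cc(OC)c1OC` gives 8800 nM in a functional assay on K562 cells (Homo sapiens) for cytotoxicity, read by MTT assay, with a stated time of 72 h; on this read-out lower numbers stand for stronger inhibition and higher numbers for weaker inhibition. Compound 2 `COc1cccc(/C=C/C(=O)c2cc3cc(O)ccc3oc2=O)c1OC` gives 17300 nM in this assay, and compound 3 `COc1cccc(/C=C/C(=O)c2cc3cc(OCc4ccccc4)ccc3oc2=O)c1OC` gives 48900 nM. The difference between the cores of compound 1 and compound 2 is not broken down here. Compound 2 and compound 3 differ by benzyl in place of hydrogen on an oxygen on an aromatic ring, and this change made a 2.8-fold higher number from compound 2 to compound 3 (0.45 log units; beyond the scatter). Compound 4 `COc1cc(/C=C/C(=O)c2cc3cc(OCc4ccccc4)ccc3oc2=O)cc(OC)c1OC` differs from compound 1 by benzyl in place of hydrogen on an oxygen on an aromatic ring. The place of the change reads the same in both pairs, so it is the same change, and its only measured outcome so far is the step from compound 2 to compound 3. On that basis compound 4 is expected to give 24000 nM in this assay, with a range from 11000 nM to 55000 nM. This amounts to an expected step of a 2.7-fold higher number from compound 1 to compound 4 (0.44 log units; beyond the scatter), resting on a 2.8-fold higher number from compound 2 to compound 3 (0.45 log units; beyond the scatter).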

Compound 4, half-maximal inhibitory concentration: 66400 nM
Estimate against measurement, compound 4: 2.8-fold (0.44 log units) below; the measured number lies above the stated range.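

On the core of compound 1, benzyl in place of hydrogen on an oxygen on an aromatic ring gave a 7.5-fold higher number from compound 1 to compound 4 (0.88 log units; beyond the scatter) in this assay, the same direction as on the core of compound 2. Set side by side, the two steps differ in size: the same change on two cores in this assay, a 2.8-fold higher number (0.45 log units; beyond the scatter) from compound 2 to compound 3 and a 7.5-fold higher number (0.88 log units; beyond the scatter) from compound 1 to compound 4, 2.7-fold (0.43 log units) apart, beyond the scatter of two such steps. The direction of the change therefore carried over between these two cores but its size did not, and two pairs neither give a rule for other cores nor show which difference between the cores goes with the gap.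

The compounds shown carry only hydroxy or benzyloxy at this oxygen. Going by these compounds, it remains open whether a methyl ether, a longer alkyl chain or a chain ending in an amine would follow the same direction on either core.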